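A few compounds are considered here, and "the series" means these few. Any claim that something is new, unique, unknown or untested is made for them only; others in the source may bear on it.

Working notes on the series.

Compound 1 `c1ccc2c(-c3cn4ccnc4c(-c4ccc5ncn(C6CCCCC6)c5c4)n3)cccc2c1` in a functional assay on KM12 cells (Homo sapiens) for inhibition, read by sulforhodamine B assay, with a stated time of 48 h, tested at 10 uM (on this read-out lower numbers stand for less inhibition and higher numbers for more inhibition at the one concentration tested (going by the name of the read-out)), gives 11.1%. Compound 2 `c1csc(-c2cn3ccnc3c(-c3ccc4ncn(C5CCCCC5)c4c3)n2)c1` in this assay gives 4.89%, and the step of a number 6.2 percentage points lower from compound 1 to compound 2 (within the scatter) is the only one measured so far. Among the compounds with values here, on these two numbers compound 2 carries the lowest value, with compound 1 as its only neighbour, and the two lie within the scatter of one another, so no order between them is claimed.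

Compound 3 `FC(F)(F)c1cccc(-c2cn3ccnc3c(-c3ccc4ncn(C5CCCCC5)c4c3)n2)c1` is not yet measured. It differs from compound 2 in one place: 3-(trifluoromethyl)phenyl in place of thiophen-2-yl on an aromatic carbon. Within the data shown here, the only step that bears on this change is the one from compound 1 to compound 2, which swapped one aromatic ring for another on the same aromatic carbon and stayed within the scatter. A six-membered aromatic ring of carbon only enters again here, comparable in kind to what compound 1 carried. The expected step of a number 4.1 percentage points higher from compound 2 to compound 3 (within the scatter) is therefore none beyond the scatter. Compound 3 is estimated at 9%, with a range from 0% to 25%.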

Compound 3, a percentage reported as inhibition, at one concentration (the size of the read-out at that concentration, not a potency): 1.25%
Compound 3: middle estimate off by 7.8 percentage points, on the high side, and the stated range covers the measured number.
By their numbers in this assay, from the lowest: compounds 3, 2 and 1 (each within the scatter of the next).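

In this assay, 3-(trifluoromethyl)phenyl on this aromatic carbon, next to the ring nitrogen, gives a number 3.6 percentage points lower from compound 2 to compound 3 (within the scatter) and a number 9.9 percentage points lower from compound 1 to compound 3 (within the scatter). The series now holds a five-membered aromatic ring with a sulfur, a naphthalen-1-yl group and a six-membered aromatic ring of carbon only bearing trifluoromethyl, and at this position the read-out does not separate any of the three, so the larger group entering here brings no step beyond the scatter. No measurement on hand offers an explanation for these numbers.

Still open, going by these compounds, is whether any group on this carbon moves the read-out beyond the scatter, for instance a non-aromatic one such as an amine, a carboxylic acid or a longer chain. Also open, on these data alone, is whether a change elsewhere, such as replacing the cyclohexyl group, would do so.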